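The source may report more compounds than this note shows. Statements on the series, on what has been measured and on what is new or still open speak of the compounds shown alone.

Measured in an ADME assay on HEK293 cells (Homo sapiens) for cytotoxicity, read by MTT assay, with a stated time of 48 h; on this read-out lower numbers stand for stronger inhibition and higher numbers for weaker inhibition:
compound 1 `COc1ccc(N/C(CCNC2=CC(=O)c3ccccc3C2=O)=N\S(=O)(=O)c2ccc(C)cc2)cc1` gives 35100 nM
compound 2 `Cc1ccc(S(=O)(=O)/N=C(/CCNC2=CC(=O)c3ccccc3C2=O)Nc2ccccc2[N+](=O)[O-])cc1` gives 69600 nM
compound 3 `COc1ccc(N/C(CCNC2=CC(=O)c3ccccc3C2=O)=N\S(=O)(=O)c2ccc(C)cc2)c(OC)c1` gives 83000 nM

Compound 3 stands at the highest of the three numbers in this assay, with compound 2 nearest and compound 1 furthest; the two gaps are a 2.4-fold higher number from compound 1 to compound 3 (0.37 log units; beyond the scatter) and a 1.2-fold higher number from compound 2 to compound 3 (0.08 log units; within the scatter). Compound 4 `Cc1ccc(S(=O)(=O)/N=C(/CCNC2=CC(=O)c3ccccc3C2=O)NC(C)C)cc1` differs from compound 3 by isopropyl in place of 2,4-dimethoxyphenyl on an amine nitrogen. Among the compounds with values here, the two steps that touch this nitrogen, a 2.4-fold higher number from compound 1 to compound 3 (0.37 log units; beyond the scatter) and a 1.2-fold higher number from compound 2 to compound 3 (0.08 log units; within the scatter), both exchange one aromatic group for another; no measured step swaps an aromatic group for an alkyl one. Both are small, so only a small step is expected from compound 3 to compound 4 in this assay, a 1.2-fold lower number from compound 3 to compound 4 (0.07 log units; within the scatter), in either direction. Compound 4 is therefore estimated at 70000 nM, in the range 30000 nM to 160000 nM.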

Compound 4, half-maximal inhibitory concentration: 71600 nM
Beside the measured number, compound 4's estimate is 1.0-fold (0.01 log units) below it; the measured number falls inside the stated range.
By their numbers in this assay, from the lowest: compounds 1, 2, 4 and 3 (each within the scatter of the next, the first and the last beyond it).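

In this assay this amine nitrogen now carries an alkyl group, and isopropyl, with no ring, reads level with two aromatic groups: a 1.2-fold lower number from compound 3 to compound 4 (0.06 log units; within the scatter) and a 1.0-fold higher number from compound 2 to compound 4 (0.01 log units; within the scatter) both lie within the scatter. Only the 4-methoxyphenyl group of compound 1 stands apart, with a 2.0-fold higher number from compound 1 to compound 4 (0.31 log units; beyond the scatter) beyond the scatter, though modest. Nothing available explains this result. Open, from the compounds shown here alone, is whether a longer chain, a cyclohexyl ring or a chain ending in an amine on this nitrogen would stay in the same range.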